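The compounds below may be only part of what the source reports. "The series", "measured", "known", "first", "only" and "open" are said of these compounds alone.

Compound 1, with the structure `CC1CCN(c2c(S(=O)(=O)c3cc(F)cc(F)c3)cnc3cc(Cl)ccc23)CC1`, was tested in an assay on isolated protein for displacement of a labelled ligand from metabotropic glutamate receptor 5 (Homo sapiens), with a stated time of 60 min, tested at 1 uM (a higher number here means more inhibition at the concentration tested (going by the name of the read-out), a lower number less inhibition), where compound 1 gives 94%. Among the three measured compounds this places compound 1 second highest. Its nearest neighbour is compound 2, `Cc1ccc(S(=O)(=O)c2cnc3ccc(Cl)cc3c2N2CCC(C)CC2)cc1`, which in this assay gives 95%, a value within the scatter of compound 1, so no order between the two can be read. Furthest away is compound 3, `O=S(=O)(c1cccc(F)c1)c1cnc2cc(Cl)ccc2c1N1CCC(CO)CC1`, which in this assay gives 71%, clearly lower than compound 1 and beyond the scatter.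

The step from compound 1 leads to compound 4, `CC1CCN(c2c(S(=O)(=O)c3ccc(Cl)cc3)cnc3cc(Cl)ccc23)CC1`, which has not yet been measured. The change is 4-chlorophenyl in place of 3,5-difluorophenyl on a sulfonyl sulfur. Compound 2 shows that a different group on the sulfonyl sulfur, next to the same core and the same methyl-bearing ring, still gives high inhibition, 95%. The expectation for compound 4 is therefore a step of a number 3 percentage points lower from compound 1 to compound 4 (within the scatter), not beyond the scatter in either direction. Compound 4 is estimated to give 91% in this assay, within a range from 80% to 98%.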

Compound 4, a percentage reported as inhibition, at one concentration (the size of the read-out at that concentration, not a potency): 91%
Beside the measured number, compound 4's estimate shows no gap at the digits printed, within the range that was stated.
By their numbers in this assay, from the lowest: compound 3; then compounds 4, 1 and 2 (each within the scatter of the next).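

Exchanging 3,5-difluorophenyl for 4-chlorophenyl on a sulfonyl sulfur gives, in this assay, a number 3 percentage points lower from compound 1 to compound 4 (within the scatter) and so no order can be read between the two groups. Within the data shown here, this is the first comparison at this position with everything else held the same, and it shows that this particular exchange of halogen-bearing phenyl groups leaves no readable difference at the single concentration tested. Nothing measured here gives a reason for this result.

The compounds shown leave open whether this position would accept a group other than a substituted phenyl, such as a pyridine ring, a morpholine or a simple methyl group. They also leave open whether a carboxylic acid or an amine on the phenyl ring would give a step beyond the scatter.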